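The compounds below may be only part of what the source reports. "The series", "measured", "known", "first", "only" and "open" are said of these compounds alone.

Measured so far in a functional assay on A549 cells (Homo sapiens) for antiproliferative activity, read by CCK-8 assay, with a stated time of 72 h; a higher number here means a weaker inhibitor, a lower number a stronger inhibitor:
compound 1 `O=C(Nc1cccc(-c2oc3cc(-c4ccc(F)cc4)ccc3c(=O)c2O)c1)c1ccccc1F`, 4410 nM
compound 2 `O=C(Nc1cccc(-c2oc3cc(-c4ccc(F)cc4)ccc3c(=O)c2O)c1)c1ccc(F)cc1`, 6930 nM
compound 3 `Cc1ccc(C(=O)Nc2cccc(-c3oc4cc(-c5ccc(F)cc5)ccc4c(=O)c3O)c2)cc1`, 6910 nM

Compound 2 is nearest to compound 3 and furthest from compound 1, yet both gaps stay within the scatter: a 1.6-fold higher number from compound 1 to compound 2 (0.20 log units; within the scatter) and a 1.0-fold lower number from compound 2 to compound 3 (0.00 log units; within the scatter). Compound 4 `O=C(Nc1cccc(-c2oc3cc(-c4ccc(F)cc4)ccc3c(=O)c2O)c1)c1ccc(Cl)cc1` is not yet measured; it differs from compound 2 by chloro in place of fluoro on an aromatic carbon. For the measured compounds named here, the one step at the same place, a 1.0-fold lower number from compound 2 to compound 3 (0.00 log units; within the scatter), showed no change, and the step of a 1.6-fold higher number from compound 1 to compound 3 (0.20 log units; within the scatter) also stayed within the scatter, so a swap of the group on this ring has not yet moved the number. No step beyond the scatter is therefore expected in this assay for compound 4. The expected step is a 1.1-fold lower number from compound 2 to compound 4 (0.03 log units; within the scatter). Compound 4 is estimated at 6500 nM, range 3000 nM to 14000 nM.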

Compound 4, half-maximal inhibitory concentration: 10800 nM
Beside the measured number, compound 4's estimate is 1.7-fold (0.22 log units) below it; the measured number falls inside the stated range.
By their numbers in this assay, from the lowest: compounds 1, 3, 2 and 4 (each within the scatter of the next, the first and the last beyond it).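

In this assay, chloro on this ring gives a 1.6-fold higher number from compound 2 to compound 4 (0.19 log units; within the scatter) when it replaces fluoro and a 1.6-fold higher number from compound 3 to compound 4 (0.19 log units; within the scatter) when it replaces methyl, so neither swap at this place leaves the scatter. For the compounds shown here, the only step beyond the scatter is modest, a 2.4-fold higher number from compound 1 to compound 4 (0.39 log units; beyond the scatter), and it swaps 2-fluorophenyl for 4-chlorophenyl, so the halogen and its place on the ring change together. No available data speak to the cause of this gap.

Going by these compounds, whether an amine, a carboxylic acid or a longer chain at this place would move the number further remains open.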